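The compounds below may be only part of what the source reports. "The series", "measured", "known", "first", "only" and "open" are said of these compounds alone.

Measured compounds:
Compound 1 `COc1ccc(-n2cc(-c3ccc(OC)c(OC)c3)nn2)c(OC)c1`: "not determined" (no result reported)
Compound 2 `COc1ccc(-n2cc(-c3ccc(O)c(OC)c3)nn2)c(OC)c1`: "not determined" (no result reported)
Compound 3 `COc1ccc(-n2cc(-c3ccc(OC)c(OC)c3)nn2)cc1`: > 100 nM

The read-out throughout is a functional assay on MDA-MB-231 cells (Homo sapiens) for cytotoxicity, read by MTT assay; a lower number here means a stronger inhibitor, a higher number a weaker inhibitor. Compound 1 has no single number here: in this assay compound 1 gives "not determined" (no result reported). Compound 2 likewise gives "not determined" (no result reported) in this assay. Compound 3 alone has an entry, and it is a limit of the assay rather than a number: in this assay compound 3 gives > 100 nM. That limit is the only anchor in the set (the limit of > 100 nM in this assay, at which 1 of the 3 values shown sits).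

Compound 4 `COc1ccc(-c2cn(-c3ccc(OC)cc3OC)nn2)cc1` has not yet been measured. It differs from compound 1 in one place (hydrogen in place of methoxy on an aromatic carbon), hydrogen in place of methoxy on an aromatic carbon. Within the data shown here, no step between two measured compounds is available, so the size and direction of this change in this assay cannot be drawn from the data; the only guide is that the single reported entry, for compound 3, is a limit on the weak side.

Compound 4 is therefore expected to sit in the weak range as well, estimated at 3000 nM, within 300 nM to 30000 nM.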

Compound 4, half-maximal inhibitory concentration: > 10000 nM
Compound 4: a limit, no number; the forecaster's own chance of this, stated with the estimate: 60%; middle value at least 3.3-fold (0.52 log units) away from the limit.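

No step can be read between compound 1 and compound 4: in this assay compound 1 has no result and compound 4 has only a limit. The compounds shown leave open how strongly any of them acts, and whether methoxy or hydrogen at that place changes the result.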